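The source may report more compounds than this note shows. Statements on the series, on what has been measured and on what is new or still open speak of the compounds shown alone.

Compound 3 `O=C(NCc1cn(Cc2ccc(C(F)(F)F)cc2)nn1)c1cn(-c2ccccc2)nc1-c1ccc(Cl)cc1` gives 4900 nM in a functional assay on MCF7 cells (Homo sapiens) for antiproliferative activity, read by sulforhodamine B assay, with a stated time of 48 h (a lower number here means a stronger inhibitor of growth, a higher number a weaker inhibitor of growth), the second highest of three numbers recorded there. Its nearest neighbour is compound 2 `O=C(NCc1cn(Cc2ccc(Cl)cc2)nn1)c1cn(-c2ccccc2)nc1-c1ccc(Cl)cc1`, which gives 28800 nM; the furthest is compound 1 `COc1ccc(Cn2cc(CNC(=O)c3cn(-c4ccccc4)nc3-c3ccc(F)cc3)nn2)cc1`, which gives 650 nM. Going by the values given here, the only step measured in one place, a 5.9-fold lower number from compound 2 to compound 3 (0.77 log units; beyond the scatter), is a modest one. The next step leads to compound 4 `COc1ccc(Cn2cc(CNC(=O)c3cn(-c4ccccc4)nc3-c3ccc(Cl)cc3)nn2)cc1`, where the change is methoxy in place of trifluoromethyl on an aromatic carbon. Among the compounds with values here, no measured step carries exactly this change, so the expectation rests on two points: the step from compound 2 to compound 3 shows that the number in this assay moves beyond the scatter when this group is exchanged, and compound 1, which already carries the methoxy that enters, gives 650 nM. Compound 4 is therefore expected to show a step of a 4.1-fold lower number from compound 3 to compound 4 (0.61 log units; beyond the scatter), a lower number than compound 3. The estimate for compound 4 is 1200 nM, with a range from 400 nM to 4000 nM.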

Compound 4, concentration for 50% growth inhibition: 8000 nM
Estimate against measurement, compound 4: 6.7-fold (0.82 log units) below; measured number above the stated range.
By their numbers in this assay, from the lowest: compound 1; then compounds 3 and 4 (each within the scatter of the next); then compound 2.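

In this assay, methoxy and trifluoromethyl on this aromatic carbon are not told apart (a 1.6-fold higher number from compound 3 to compound 4 (0.21 log units; within the scatter)), whereas methoxy in place of chloro at the same carbon does move the number (a 3.6-fold lower number from compound 2 to compound 4 (0.56 log units; beyond the scatter)), so among these three groups chloro alone stands apart. With the 4-methoxybenzyl held constant, chloro in place of fluoro on the other aromatic ring gives a large step (a 12-fold higher number from compound 1 to compound 4 (1.09 log units; beyond the scatter)), so the low number of compound 1 goes with the fluoro and not with the methoxy alone.

On these data alone, whether fluoro would bring a similar gain with trifluoromethyl or chloro on the benzyl ring remains open. So does the effect of an amine or a carboxylic acid on this aromatic carbon. No measurement given here accounts for these steps.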